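The source may report more compounds than this note shows. Statements on the series, on what has been measured and on what is new or still open speak of the compounds shown alone.

Measured compounds:
compound 1, `Cc1cc(NC(=O)C2CCCO2)nn1Cc1cc(Cl)ccc1OCc1ccccc1`, in an assay on CHO-K1 cells for displacement of a labelled ligand from prostaglandin E2 receptor EP1 subtype (Homo sapiens) (a lower number here means a stronger inhibitor, a higher number a weaker inhibitor), gives 39.8 nM
compound 2, `Cc1cc(NC(=O)c2ccccc2)nn1Cc1cc(Cl)ccc1OCc1ccccc1`, in this assay gives 15.9 nM

Going by the values given here, compound 2 stands lowest of the two numbers in this assay; its nearest neighbour is compound 1, and the single step on record is a 2.5-fold lower number from compound 1 to compound 2 (0.40 log units; beyond the scatter), a modest gain on exchanging a saturated ring for an aromatic one on the carbonyl carbon.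

Compound 3, `CCOC(=O)Nc1cc(C)n(Cc2cc(Cl)ccc2OCc2ccccc2)n1`, is not yet measured. Relative to compound 2 the change is ethoxy in place of phenyl on a carbonyl carbon; cut one bond further out it reads benzoyl to ethoxycarbonyl, benzamido to (ethoxycarbonyl)amino.

Among the compounds with values here, only that one measured step bears on the question, and loosely: it shows that a non-aromatic group in place of phenyl at this carbonyl carbon raised the number, and ethoxy is likewise without a ring. Within the data shown here, a modest rise in this assay is therefore expected for compound 3, opposite in direction to the measured step and of comparable size, though the carbamate has no direct precedent in the set.

For compound 3 the expected value in this assay is 50 nM, with a range of 15 nM to 160 nM. The expected step is a 3.1-fold higher number from compound 2 to compound 3 (0.50 log units; beyond the scatter).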

Compound 3, half-maximal inhibitory concentration: 79.4 nM
Compound 3: the middle estimate sits 1.6-fold (0.20 log units) below what was measured; measured number inside the range.
By their numbers in this assay, from the lowest: compound 2; then compounds 1 and 3 (each within the scatter of the next).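

Exchanging phenyl for ethoxy on the carbonyl carbon, which turns benzamido into (ethoxycarbonyl)amino, gives a 5.0-fold higher number from compound 2 to compound 3 (0.70 log units; beyond the scatter) in this assay and confirms that this position responds to the group carried there. Compound 2 now holds the lowest number against two replacements that lack an aromatic ring, so the preference for phenyl no longer rests on oxolan-2-yl alone. The two replacements themselves stay unresolved, with a 2.0-fold higher number from compound 1 to compound 3 (0.30 log units; within the scatter) despite the ring present in oxolan-2-yl and absent from ethoxy, and nothing on hand accounts for the preference for phenyl.

The compounds shown leave open whether the lower number of compound 2 tracks the aromatic ring itself or simply the larger group, and a benzyloxy group on the same carbonyl carbon would test this within the carbamate form of compound 3. Also open, going by these compounds, is how far the number at this position depends on the atom joined to the carbonyl carbon, which a dimethylamino group or a propyl chain in place of ethoxy would begin to address.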